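The compounds below may be only part of what the source reports. "The series", "measured", "known", "first", "only" and "open" are said of these compounds alone.

Measured compounds in an assay on cells for inhibition of HSP60/HSP10 (Homo sapiens), with a stated time of 60 min; on this read-out lower numbers stand for stronger inhibition and higher numbers for weaker inhibition:
- compound 1, `O=S(=O)(Nc1ccc(-c2nc3ccccc3o2)cc1)c1ccccc1Cl`: > 100000 nM
- compound 2, `CS(=O)(=O)Nc1ccc(-c2nc3cc(NS(=O)(=O)c4ccc(Cl)s4)ccc3o2)cc1`: 43000 nM
- compound 3, `O=S(=O)(Nc1ccc2oc(-c3ccccc3)nc2c1)c1ccc(F)c(C(F)(F)F)c1`: 69000 nM

The reading for compound 1 is a limit of this assay and not a number, which is the point made by the limit of > 100000 nM in this assay, at which 1 of the 3 values shown sits. Compound 1 therefore stands at the weak end of what has been measured, with no number of its own to set against the values of compound 2 or compound 3, both of which did return numbers in this assay.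

Compound 4, `O=S(=O)(Nc1ccc(-c2nc3ccccc3o2)cc1)c1ccc(F)cc1`, has not been measured. Its change from compound 1 is 4-fluorophenyl in place of 2-chlorophenyl on a sulfonyl sulfur. Going by the values given here, no step between two measured compounds touches this part of the molecule, so nothing in the measured set shows how the aryl group on the sulfonyl sulfur moves this assay.

With that, the expectation is that the step of a number no higher from compound 1 to compound 4 (the limit leaves the size open) is none beyond the scatter. Compound 4 is expected to give about 100000 nM in this assay, with a range from 40000 nM to 300000 nM, and a limit rather than a number is the more likely outcome.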

Compound 4, half-maximal inhibitory concentration: 73000 nM
The estimate for compound 4 lay 1.4-fold (0.14 log units) above the measured number; low and high end bracket the measured number.
By their numbers in this assay, from the lowest: compounds 2, 3 and 4 (each within the scatter of the next). At a limit, above all of these: compound 1.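

In this assay, going by these compounds alone, the first step at the aryl group on the sulfonyl sulfur is an at least 1.3-fold lower number from compound 1 to compound 4 (0.13 log units; that floor lies within the scatter), with 4-fluorophenyl in place of 2-chlorophenyl. The reading for compound 1 remains a limit of this assay and not a number. With this aryl change, compound 4 gives a measured value of 73000 nM. The true size of the step remains unknown because one end of it is a limit: the limit of > 100000 nM in this assay, at which 1 of the 4 values shown sits.

This single step changes both the halogen and its place on the phenyl ring, and the compounds shown do not separate the two. Also open, as far as these compounds go, is how this assay responds to an amine or a carboxylic acid on that phenyl ring, with the rest of compound 4 unchanged.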